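This account rests on a few compounds, and the source may have more. Where it says the series, first, only, none or still open, it means among the compounds named here.

Compounds measured in an assay for inhibition of Nitric oxide synthase, inducible (Homo sapiens), read by scintillation counting, with a stated time of 30 min, tested at 1 mM; on this read-out higher numbers stand for more inhibition at the one concentration tested (going by the name of the read-out) and lower numbers for less inhibition:
Compound 1, `CCCNC(=S)NCCC(O)c1ccccc1N`, gave 31.1%.
Compound 2, `CCNC(=O)NCCC(O)c1ccccc1N`, gave 18.3%.
Compound 3, `CCCNC(=S)NCCC(O)c1cc(Cl)ccc1N`, gave 55%.

Compound 2 differs from compound 1 by a group of 5 heavy atoms (3 carbon, 1 nitrogen, 1 oxygen; no ring) in place of a group of 6 heavy atoms (4 carbon, 1 nitrogen, 1 sulfur; no ring), on an amine nitrogen. In this assay this change produced a number 12.8 percentage points lower from compound 1 to compound 2 (beyond the scatter). Compound 3 differs from compound 1 by chloro in place of hydrogen on an aromatic carbon, and in this assay that change gave a number 23.9 percentage points higher from compound 1 to compound 3 (beyond the scatter), so compound 3 stands highest of the three measured compounds.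

Compound 4, `CCNC(=O)NCCC(O)c1cc(Cl)ccc1N`, has not been measured. It differs from compound 3 by a group of 5 heavy atoms (3 carbon, 1 nitrogen, 1 oxygen; no ring) in place of a group of 6 heavy atoms (4 carbon, 1 nitrogen, 1 sulfur; no ring), on an amine nitrogen, which is the same change as that from compound 1 to compound 2, at the same place. Within the data shown here, on this basis a step of similar size is expected, a number 13 percentage points lower from compound 3 to compound 4 (beyond the scatter), because the earlier instance of this change gave a number 12.8 percentage points lower from compound 1 to compound 2 (beyond the scatter) and only one instance of it is known, so the expectation carries its own uncertainty. In this assay compound 4 is estimated at 42%, with a range from 27% to 55%.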

Compound 4, a percentage reported as inhibition, at one concentration (the size of the read-out at that concentration, not a potency): 33.9%
For compound 4 the middle estimate is 8.1 percentage points above the measured one; the range from low to high includes it.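

In this assay ethylcarbamoyl in place of the group of 6 heavy atoms on the amine nitrogen carried over to the core of compound 3, giving a number 21.1 percentage points lower from compound 3 to compound 4 (beyond the scatter), and the two instances agree: the same change on two cores in this assay, a number 12.8 percentage points lower (beyond the scatter) from compound 1 to compound 2 and a number 21.1 percentage points lower (beyond the scatter) from compound 3 to compound 4, 8.3 percentage points apart, within the scatter of two such steps. Chloro in place of hydrogen carried over likewise, giving a number 15.6 percentage points higher from compound 2 to compound 4 (beyond the scatter): the same change on two cores in this assay, a number 23.9 percentage points higher (beyond the scatter) from compound 1 to compound 3 and a number 15.6 percentage points higher (beyond the scatter) from compound 2 to compound 4, 8.3 percentage points apart, within the scatter of two such steps. This rests on two cores only and does not show that either step would hold on any other core.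

The compounds shown leave open how much of the first step belongs to oxygen in place of sulfur and how much to the chain, as the two change together. They also leave open how a bromo or methoxy group would read in place of chloro.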